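Three values at the assay limit and one unmeasured dihydroxybenzyl analogue

The source may hold more compounds than are shown below. What is called first, only, known or untested is meant among the compounds shown, and "the series" means these compounds.

Measured so far in a functional assay on HOS cells (Homo sapiens) for antiproliferative activity, with a stated time of 72 h; a higher number here means a weaker inhibitor, a lower number a stronger inhibitor:
compound 1 `OC[C@H]1O[C@@H](n2cnc3c(NCc4cccc(F)c4)ncnc32)[C@H](O)[C@@H]1O` gives > 166000 nM
compound 2 `OC[C@H]1O[C@@H](n2cnc3c(NCc4cccc(Br)c4)ncnc32)[C@H](O)[C@@H]1O` gives > 166000 nM
compound 3 `OC[C@H]1O[C@@H](n2cnc3c(NCc4ccc(Cl)c(Cl)c4)ncnc32)[C@H](O)[C@@H]1O` gives > 166000 nM

The value of compound 1 is a limit of this assay and not a number. The value of compound 2 is likewise a limit. The value of compound 3 is likewise a limit. Compound 2 therefore stands only at a limit, and the two further values shown are limits as well (the limit of > 166000 nM in this assay, at which 3 of the 3 values shown sit). The steps between the measured compounds are accordingly unreadable: a step that the two limits leave unreadable from compound 1 to compound 2; a step that the two limits leave unreadable from compound 1 to compound 3; a step that the two limits leave unreadable from compound 2 to compound 3. None of them gives a size or a direction that could be carried forward.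

The next compound is compound 4 `OC[C@H]1O[C@@H](n2cnc3c(NCc4cccc(O)c4O)ncnc32)[C@H](O)[C@@H]1O`. It differs from compound 2 as follows: 2,3-dihydroxyphenyl in place of 3-bromophenyl on a saturated chain carbon bound to a nitrogen on an aromatic ring.

Among the compounds with values here, no measured step bears on this change with a readable size, since all three sit at the limit. The expectation for compound 4 therefore rests on that shared limit alone, with wide uncertainty in both directions. Compound 4 is expected to give about 166000 nM in this assay, within 40000 nM to 700000 nM. The step this estimate means is a number no higher from compound 2 to compound 4 (the limit leaves the size open), expected to remain unreadable against the limit.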

Compound 4, half-maximal inhibitory concentration: > 166000 nM
Compound 4 ended at the assay's limit; the forecaster's own chance of this, stated with the estimate: 70%; the middle value sits exactly at the limit.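

In this assay, no step between compound 4 and compound 1, compound 2 or compound 3 can be read, since all four compounds share one limit: the limit of > 166000 nM in this assay, at which 4 of the 4 values shown sit.

The compounds shown leave open how far each lies past that limit, and so whether 3-bromobenzyl and 2,3-dihydroxybenzyl differ at all in this assay.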